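A few compounds are considered here, and "the series" means these few. Any claim that something is new, unique, unknown or untested is made for them only; others in the source may bear on it.

Compound 1 `O=C(/N=C(/NC(=O)c1ccno1)[Se]Cc1ccccc1)c1ccno1` is a selenium-containing compound carrying two identical heteroaromatic amide arms. In an ADME assay on MCF-10A cells (Homo sapiens) for cytotoxicity, read by MTT assay, with a stated time of 72 h (on this read-out lower numbers stand for stronger inhibition of growth and higher numbers for weaker inhibition of growth), compound 1 gives 7800 nM. Compound 2 `C[Se]/C(=N\C(=O)c1ccno1)NC(=O)c1ccno1` differs from it only in one place (hydrogen in place of phenyl on a saturated chain carbon bound to a selenium atom), and in this assay compound 2 gives 2890 nM, a change of a 2.7-fold lower number from compound 1 to compound 2 (0.43 log units; beyond the scatter). Compound 3 `O=C(/N=C(/NC(=O)c1csc([N+](=O)[O-])c1)[Se]Cc1ccccc1)c1csc([N+](=O)[O-])c1` keeps the benzyl group on selenium but has a different pair of amide arms; the difference between its core and that of compound 1 is not broken down here. In this assay compound 3 gives 24400 nM, the highest of the three numbers. Compound 4 `C[Se]/C(=N\C(=O)c1csc([N+](=O)[O-])c1)NC(=O)c1csc([N+](=O)[O-])c1` is not yet measured and differs from compound 3 by hydrogen in place of phenyl on a saturated chain carbon bound to a selenium atom, the same change seen between compound 1 and compound 2. Compound 4 is expected to show a 2.6-fold lower number from compound 3 to compound 4 (0.41 log units; beyond the scatter), because the matching change gave a 2.7-fold lower number from compound 1 to compound 2 (0.43 log units; beyond the scatter). Compound 4 is therefore estimated at 9500 nM, within a range from 4500 nM to 20000 nM.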

Compound 4, concentration for 50% growth inhibition: 1950 nM
Beside the measured number, compound 4's estimate is 4.9-fold (0.69 log units) above it; the whole stated range lies above it.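

In this assay, going from benzyl to methyl on selenium gives a 13-fold lower number from compound 3 to compound 4 (1.10 log units; beyond the scatter) as a large step. The number falls on both cores, but the size of the fall does not carry over from one core to the other: the same change on two cores in this assay, a 2.7-fold lower number (0.43 log units; beyond the scatter) from compound 1 to compound 2 and a 13-fold lower number (1.10 log units; beyond the scatter) from compound 3 to compound 4, 4.6-fold (0.67 log units) apart, beyond the scatter of two such steps
Two pairs therefore show a shared direction, but they give no reliable size for this change on another core and do not show what sets the two steps apart.

On these data alone, it remains open how an ethyl or propyl chain on selenium would compare with methyl and benzyl. As far as these compounds go, it also remains open how large the step would be with amide arms carrying a carboxylic acid or an amine.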